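This account rests on a few compounds, and the source may have more. Where it says the series, first, only, none or still open, it means among the compounds named here.

Measured so far in an ADME assay on microsomes from liver (Mus musculus) for metabolic stability; on this read-out lower numbers stand for a shorter-lived compound and higher numbers for a longer-lived compound:
- Compound 1 `CC(C)C(Cc1ncc[nH]1)c1ccc(-c2ccc3cccc(F)c3c2)[nH]c1=O`: < 0.0667 h, a limit of the assay
- Compound 2 `CC(C)C(Nc1nnc[nH]1)c1ccc(-c2ccc3cccc(F)c3c2)[nH]c1=O`: 2.42 h
- Compound 3 `CC(C)C(c1ncco1)c1ccc(-c2ccc3cccc(F)c3c2)[nH]c1=O`: 0.08 h

Compound 3, at 0.08 h, holds the lower of the two true numbers in this assay. Its distance from the other number is large: a 30-fold lower number from compound 2 to compound 3 (1.48 log units; beyond the scatter). The entry for compound 1 is a limit and not a number, and the comparison with it gives an at least 1.1-fold higher number from compound 1 to compound 3 (0.07 log units; that floor lies within the scatter).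

The next compound is compound 4 `CC(C)C(Cc1nnc[nH]1)c1ccc(-c2ccc3cccc(F)c3c2)[nH]c1=O`. It arises from compound 3 by one change: (4H-1,2,4-triazol-3-yl)methyl in place of 1,3-oxazol-2-yl on a saturated chain carbon bound to an aromatic carbon and a saturated chain carbon. In words, (4H-1,2,4-triazol-3-yl)methyl takes the place of 1,3-oxazol-2-yl. Compound 4 thus shares its 4H-1,2,4-triazol-3-yl group with compound 2, where it is attached through amino, and its methyl link with compound 1, where it carries 1H-imidazol-2-yl.

The step that bears most directly is an at least 36-fold higher number from compound 1 to compound 2 (1.55 log units; beyond the scatter). It is large, but it alters the group and the link together, so the data do not separate the two. Compound 4 keeps only the triazolyl part of that change, so a modest rise is expected, far short of the full step. The expected size is a 3.8-fold higher number from compound 3 to compound 4 (0.57 log units; beyond the scatter). For compound 4 the estimate is 0.3 h, with an expected range of 0.07 h to 1.5 h.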

Compound 4, half-life: < 0.0667 h
Compound 4 gave a limit, no number; the forecaster's own chance of this, stated with the estimate: 15%; at least 4.4-fold (0.65 log units) between middle value and limit.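

With the 4H-1,2,4-triazol-3-yl group held the same, exchanging the amino link for a methyl link gives an at least 36-fold lower number from compound 2 to compound 4 (1.55 log units; beyond the scatter), so the link alone accounts for a large step in this pair, something the step between compound 1 and compound 2 could not separate from the change of group. The triazolyl group on a methyl link also brings no readable gain over the 1,3-oxazol-2-yl group in this assay: the comparison gives an at least 1.1-fold lower number from compound 3 to compound 4 (0.07 log units; that floor lies within the scatter), a floor within the scatter, so no order can be stated. Compound 1 and compound 4 both stand at a limit and not at a number, so the step between them cannot be read, and the exchange of 1H-imidazol-2-yl for the triazolyl group on the methyl link has no measurable size: the limit of < 0.0667 h in this assay, at which 2 of the 4 values shown sit.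

From the compounds shown here alone, the amino link appears only in compound 2, so it remains open whether it would raise the half-life with 1,3-oxazol-2-yl or 1H-imidazol-2-yl in place of the triazolyl group. Going by these compounds, it is also open whether a different link on the same saturated chain carbon, such as an ether oxygen or an amide, would behave like the amino link or like the methyl link.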